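From 2,5-dimethoxyphenyl to (4-ethoxyphenyl)amino in compound 3

This account rests on a few compounds, and the source may have more. Where it says the series, first, only, none or still open, it means among the compounds named here.

Among the compounds with values here, in a functional assay on HeLa cells (Homo sapiens) for antiproliferative activity, read by MTT assay, with a stated time of 72 h (on this read-out higher numbers stand for weaker inhibition and lower numbers for stronger inhibition), compound 2 (`COc1ccc(OC)c(-c2c(C(=O)c3cc(OC)c(OC)c(OC)c3)sc3ccccc23)c1`) gives 10000 nM, the highest of the two numbers so far. In this assay, compound 1 (`COc1cc(C(=O)c2sc3ccccc3c2-c2ccc(C)cc2)cc(OC)c1OC`) gives 3700 nM. Within the data shown here, the one measured step is a 2.7-fold higher number from compound 1 to compound 2 (0.43 log units; beyond the scatter), a modest change on the same aromatic carbon that changes next.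

Compound 3 (`CCOc1ccc(Nc2c(C(=O)c3cc(OC)c(OC)c(OC)c3)sc3ccccc23)cc1`) carries (4-ethoxyphenyl)amino in place of 2,5-dimethoxyphenyl on an aromatic carbon of a five-membered aromatic ring with 1 sulfur, two ring bonds from the ring sulfur: (4-ethoxyphenyl)amino in place of 2,5-dimethoxyphenyl on an aromatic carbon. Among the measured compounds shown here, no measured compound has an amino link at this carbon, so the single step offers a scale but no firm direction. The expectation of a lower number rests on compound 2 being the higher of the pair, with compound 1 at 3700 nM for a different group at this place. The expected change, of similar modest size, is a 3.3-fold lower number from compound 2 to compound 3 (0.52 log units; beyond the scatter). For compound 3 the estimated value is 3000 nM, with an expected range of 600 nM to 12000 nM.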

Compound 3, half-maximal inhibitory concentration: 700 nM
For compound 3 the middle estimate is 4.3-fold (0.63 log units) above the measured one, within the range that was stated.
By their numbers in this assay, from the lowest: compound 3; then compound 1; then compound 2.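

Notes on the aromatic carbon two ring bonds from the ring sulfur: in this assay, the change to (4-ethoxyphenyl)amino gives a 14-fold lower number from compound 2 to compound 3 (1.15 log units; beyond the scatter) and is the first large step at this place, well beyond the modest step between the two groups without an amino link. The comparison with 4-methylphenyl points the same way, with a 5.3-fold lower number from compound 1 to compound 3 (0.72 log units; beyond the scatter), so the order among these three compounds is set by more than the substituents on a directly attached aromatic ring, and compound 3 has the lowest number, with its steps to both others printed as beyond the scatter. No supporting data bear on the reason for either step.

The entering group differs from both earlier groups in its amino link and in its ring substituent together, so the compounds shown leave open how much of the gain belongs to the link and how much to the 4-ethoxy group. A (4-methylphenyl)amino group would pair directly with compound 1 and isolate the link, while an N-methyl amine or an ether oxygen at the same place would test whether the amine hydrogen matters.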